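A few compounds are considered here, and "the series" means these few. Any claim that something is new, unique, unknown or untested is made for them only; others in the source may bear on it.

Measured in a functional assay on HepG2 cells (Homo sapiens) for antiproliferative activity, read by sulforhodamine B assay, with a stated time of 72 h; a higher number here means a weaker inhibitor of growth, a lower number a stronger inhibitor of growth:
- Compound 1 `COC1=CC(=O)[C@@]2(c3cc(=O)c4ccc(OC)cc4o3)[C@H](C[C@]3(C)[C@@H](C(=O)O)CC=C4[C@H]3CCCC4(C)C)C(C)=CC[C@H]2C1=O`: > 10000 nM
- Compound 2 `COC1=CC(=O)[C@@]2(c3cc(=O)c4ccc(O)cc4o3)[C@H](CC=C(C)[C@@H]2C[C@]2(C)[C@@H](C(=O)O)CC=C3[C@H]2CCCC3(C)C)C1=O`: > 10000 nM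

Compound 2 stands at > 10000 nM, which is a limit of the assay and not a number. The same holds for the other measured compound: the limit of > 10000 nM in this assay, at which 2 of the 2 values shown sit. Compound 3 `COC1=CC(=O)[C@@]2(c3cc(=O)c4ccc(O)cc4o3)[C@H](C[C@]3(C)[C@@H](C(=O)O)CC=C4[C@H]3CCCC4(C)C)C(C)=CC[C@H]2C1=O` is related to compound 2 as follows: the two compounds have the same atoms and bonds and differ only in configuration as drawn: 3 of 6 stereo elements differ; a stereocentre at a saturated ring carbon is drawn R in compound 2 and S in compound 3; a stereocentre at a saturated ring carbon is drawn S in compound 2 and R in compound 3; a stereocentre at a saturated ring carbon is drawn S in compound 2 and R in compound 3. With no number to start from, no step beyond the usual scatter is expected in this assay, in either direction. The estimated change is a number no higher from compound 2 to compound 3 (the limit leaves the size open). Compound 3 is expected near 10000 nM, with an estimated range of 3000 nM to 20000 nM.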

Compound 3, concentration for 50% growth inhibition: > 10000 nM
Compound 3: no number, only a limit; the forecaster's own chance of this, stated with the estimate: 70%; the middle value sits exactly at the limit.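

Compound 3 gives > 10000 nM in this assay, which is a limit of the assay and not a number, so its steps from compound 1 and compound 2 cannot be read. The compounds shown leave open whether the configuration as drawn, or hydrogen in place of methyl on an oxygen on an aromatic ring, changes growth inhibition.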